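This account rests on a few compounds, and the source may have more. Where it says the series, first, only, none or still open, it means among the compounds named here.

Measured so far:
Compound 1 `C/C=C/C(=O)N(Cc1ccc(OC)c([N+](=O)[O-])c1)c1cc(OC)c(OC)c(OC)c1` gives 590 nM in a functional assay on MGC-803 cells (Homo sapiens) for inhibition, read by MTT assay, with a stated time of 48 h; a higher number here means a weaker inhibitor, a lower number a stronger inhibitor.
Compound 2 `CCCCC(=O)N(Cc1ccc(OC)c(O)c1)c1cc(OC)c(OC)c(OC)c1` gives 66 nM in this assay.
Compound 3 `C/C=C/C(=O)N(Cc1cc(OC)c(OC)c(OC)c1)c1ccc(OC)c(O)c1` gives 6150 nM in this assay.

Among these three, compound 2 stands at the lowest number and is therefore the strongest inhibitor of the set: compound 1 lies at a higher number by a margin beyond the scatter, and compound 3 higher still, also beyond the scatter. Compound 1 and compound 3 both carry a different acyl group from compound 2, but each also differs from it elsewhere, so their values cannot be read as a statement about the acyl group alone. Within the data shown here, no pair of measured compounds differs in a single place.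

Compound 4 `C=C(C)C(=O)N(Cc1ccc(OC)c(O)c1)c1cc(OC)c(OC)c(OC)c1` has not yet been measured. It differs from compound 2 at the carbonyl carbon whose other neighbour is the amide-type nitrogen: 1-methylethenyl in place of butyl on a carbonyl carbon. Among the measured compounds shown here, with no measured step of this kind to lean on, the expectation rests on compound 2 alone. The change is expected to move the number only slightly upward, within the scatter, as a 1.7-fold higher number from compound 2 to compound 4 (0.22 log units; within the scatter). In this assay compound 4 is estimated at 110 nM, with a range from 30 nM to 450 nM.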

Compound 4, half-maximal inhibitory concentration: 390 nM
The estimate for compound 4 lay 3.5-fold (0.55 log units) below the measured number; measured number inside the range.
By their numbers in this assay, from the lowest: compound 2; then compounds 4 and 1 (each within the scatter of the next); then compound 3.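

In this assay, among these compounds, the exchange of butyl for 1-methylethenyl on the carbonyl carbon whose other neighbour is the amide-type nitrogen gives a 5.9-fold higher number from compound 2 to compound 4 (0.77 log units; beyond the scatter), the first step that can be read at a single place. It shows that this position is not indifferent to the group it carries: with the rest of the structure held constant, a modest change in the acyl group alone moves the number beyond the scatter, in the direction of a weaker inhibitor. The butyl group, with its 4 carbon, is the better of the two groups compared here, while the 1-methylethenyl group brings 3 carbon and a double bond outside aromatic rings. Nothing available here gives a reason for this step.

Among the compounds shown here, the single step cannot say whether the shorter chain or the double bond carries the change, and an isopropyl group on the same carbonyl carbon would begin to separate the two. On these data alone, how a longer chain such as hexyl, or a cyclopropyl group, would fare at this place also remains open.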